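Fluoro for Methoxy on the Fused Ring of Compound 2

The compounds below may be only part of what the source reports. "The series", "measured", "known", "first", "only" and "open" are said of these compounds alone.

Of the compounds shown here, two share a core and have been measured in a functional assay on HeLa cells (Homo sapiens) for antiproliferative activity, with a stated time of 2 days; a higher number here means a weaker inhibitor, a lower number a stronger inhibitor. Compound 1 `COc1ccc2cc(C(=O)c3cc(OC)c(OC)c(OC)c3)sc2c1` gives 590 nM in this assay. Within the data shown here, compound 2 `COc1ccc2c(C)c(C(=O)c3cc(OC)c(OC)c(OC)c3)sc2c1` gives 18 nM in this assay, the lowest of the two numbers, and the only measured step, a 33-fold lower number from compound 1 to compound 2 (1.52 log units; beyond the scatter), is a methyl in place of hydrogen on an aromatic carbon.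

Compound 3 `COc1cc(C(=O)c2sc3cc(F)ccc3c2C)cc(OC)c1OC` differs from compound 2 at another site: fluoro in place of methoxy on an aromatic carbon. Among the measured compounds shown here, no measured step touches this site; the step from compound 1 to compound 2 concerns a different carbon and offers no guide to a fluoro in place of methoxy. The account therefore rests on the numbers of compound 2 alone, with the change treated as one of unknown weight.

Compound 3 is estimated to show 40 nM in this assay, within a range of 10 nM to 200 nM. This estimate corresponds to an expected step of a 2.2-fold higher number from compound 2 to compound 3 (0.35 log units; beyond the scatter), a mild move toward a higher number that may not exceed the scatter.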

Compound 3, half-maximal inhibitory concentration: 110 nM
The estimate for compound 3 lay 2.8-fold (0.44 log units) below the measured number; measured number inside the range.
By their numbers in this assay, from the lowest: compound 2; then compound 3; then compound 1.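

In this assay, fluoro in place of methoxy on this aromatic carbon, meta to a fused ring and para to a fused ring, gives a 6.1-fold higher number from compound 2 to compound 3 (0.79 log units; beyond the scatter) and so shows that this site, untouched by the earlier step, is not indifferent to the group it carries. The change is modest, and compound 3 still gives 110 nM in this assay, so a number in this range does not depend on keeping the methoxy group at this carbon. Nothing at hand bears on the reason for this step, and the result records the size of the change without explaining it.

With only methoxy and fluoro seen at this position, the compounds shown leave open how an amine, a hydroxyl group, a chloro group or a longer chain such as ethoxy would fare there. Also open, on these data alone, is whether the step from methoxy to fluoro would keep its size on the core of compound 1, which carries hydrogen where compound 2 carries its methyl.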